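The source may report more compounds than this note shows. Statements on the series, on what has been measured and on what is new or still open speak of the compounds shown alone.

Compound 1 `COc1ccc(Nc2ncc3cc(S(=O)(=O)c4ccc(C)cc4)c(=O)n(C)c3n2)cc1`: 100000 nM
Compound 2 `Cn1c(=O)c(S(=O)(=O)c2ccc(F)cc2F)cc2cnc(Nc3ccc4sccc4c3)nc21`: 500 nM

Both values come from a functional assay on DU-145 cells (Homo sapiens) for inhibition, read by trypan blue exclusion, with a stated time of 72 h; a lower number here means a stronger inhibitor, a higher number a weaker inhibitor. Compound 2 has the lower number of the two, so it is the stronger inhibitor, and its gap to compound 1 lies well beyond the usual scatter. These two compounds differ in more than one place, so they show no effect of any single change.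

Compound 3 `Cn1c(=O)c(S(=O)(=O)c2ccc(F)cc2F)cc2cnc(Nc3ccc4c(c3)CC(=O)N4)nc21` alters compound 2 in one place: a group of 10 heavy atoms (8 carbon, 1 nitrogen, 1 oxygen; one five-membered non-aromatic ring with 1 hetero atom, one six-membered aromatic ring of carbon only) in place of a group of 9 heavy atoms (8 carbon, 1 sulfur; one five-membered aromatic ring with 1 hetero atom, one six-membered aromatic ring of carbon only), on a nitrogen on an aromatic ring. Within the data shown here, with no measured precedent for this swap, only a modest step toward weaker inhibition in this assay is expected. The estimated change is a 3.0-fold higher number from compound 2 to compound 3 (0.48 log units; beyond the scatter). For compound 3 the expected value is 1500 nM, with an estimated range of 200 nM to 8000 nM.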

Compound 3, half-maximal inhibitory concentration: 100000 nM
The estimate for compound 3 lay 67-fold (1.82 log units) below the measured number; the measured number lies above the stated range.
By their numbers in this assay, from the lowest: compound 2; then compounds 1 and 3 (each within the scatter of the next).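

On a nitrogen on an aromatic ring, the 1-benzothiophen-5-yl group cannot be swapped freely: in this assay, the group with the five-membered non-aromatic ring gives a 200-fold higher number from compound 2 to compound 3 (2.30 log units; beyond the scatter). Among these compounds, this is the first single change that can be read here, and it shows that inhibition depends strongly on the group at this place. Nothing available explains the loss.

Which part of the swap matters stays open: the sulfur-containing ring, the carbonyl and the amide hydrogen all change together. An indol-5-yl or benzofuran-5-yl group at this place could begin to separate them.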